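This account rests on a few compounds, and the source may have more. Where it says the series, first, only, none or still open, it means among the compounds named here.

In an ADME assay on MT4 cells (Homo sapiens) for cytotoxicity, read by MTT assay (on this read-out higher numbers stand for lower toxicity in this test and lower numbers for higher toxicity in this test), three compounds sharing one core have been measured. Compound 1 `Cc1cc(C)cc(S(=O)(=O)c2c(C(=O)NC(C)C(=O)NCCn3c(C)cnc3[N+](=O)[O-])[nH]c3ccc(Cl)cc23)c1` gives 16000 nM, compound 2 `Cc1cc(C)cc(S(=O)(=O)c2c(C(=O)NC(C)C(=O)NCc3ccncc3)[nH]c3ccc(Cl)cc23)c1` gives 19500 nM, and compound 3 `Cc1cc(C)cc(S(=O)(=O)c2c(C(=O)NCC(=O)NCCn3c(C)cnc3[N+](=O)[O-])[nH]c3ccc(Cl)cc23)c1` gives 24500 nM. Compound 2 sits in the middle of these three numbers: the step of a 1.2-fold higher number from compound 1 to compound 2 (0.09 log units; within the scatter) is small, and the values of compound 2 and compound 3 likewise lie within the scatter of each other, so the three compounds are not distinguishable in this assay.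

Compound 4 `Cc1cc(C)cc(S(=O)(=O)c2c(C(=O)NC(C)c3cc(F)cc(F)c3)[nH]c3ccc(Cl)cc23)c1` is the next compound. Its change from compound 2 is 3,5-difluorophenyl in place of ((pyridin-4-yl)methyl)carbamoyl on a saturated chain carbon bound to an amide-type nitrogen and a saturated chain carbon. Among the measured compounds shown here, two measured steps touch the same region of the molecule: a 1.2-fold higher number from compound 1 to compound 2 (0.09 log units; within the scatter) swapped one terminal aromatic ring for another, and a 1.5-fold higher number from compound 1 to compound 3 (0.19 log units; within the scatter) removed a methyl; both were within the scatter. For the measured compounds named here, the change to compound 4 is larger, since the carbamoyl link itself leaves, and no measured step tests that. Compound 4 is therefore expected to show a step of a 1.1-fold lower number from compound 2 to compound 4 (0.06 log units; within the scatter), not beyond the scatter, with the estimate 17000 nM and a range from 6000 nM to 45000 nM to reflect the untested change.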

Compound 4, half-maximal cytotoxic concentration: > 49700 nM
Compound 4 was reported as a limit; the forecaster's own chance of this, stated with the estimate: 10%; middle value at least 2.9-fold (0.46 log units) from the limit.
By their numbers in this assay, from the lowest: compounds 1, 2 and 3 (each within the scatter of the next). At a limit, above all of these: compound 4.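

In this assay, replacing ((pyridin-4-yl)methyl)carbamoyl with 3,5-difluorophenyl on a saturated chain carbon bound to an amide-type nitrogen and a saturated chain carbon gives an at least 2.5-fold higher number from compound 2 to compound 4 (0.40 log units; beyond the scatter), the only step shown that lies beyond the scatter. The earlier changes all kept the carbamoyl link and stayed within the scatter, so this position is the first shown to respond, in the direction of lower toxicity in this test. Compound 4 was reported only as a limit, so the full size of the step stays unknown: the limit of > 49700 nM in this assay, at which 1 of the 4 values shown sits.

The compounds shown leave open whether the shift follows the loss of the carbamoyl link or the arrival of the 3,5-difluorophenyl ring, as both changed in one step. They also leave open how a plain phenyl, a pyridin-4-yl ring directly on that carbon, an amine or a carboxylic acid would read at this place.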